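A Hydroxyethyl Amide of a Dimethoxy Indane Acid

The source may report more compounds than this note shows. Statements on the series, on what has been measured and on what is new or still open speak of the compounds shown alone.

Compound 1 `COc1cc2c(cc1OC)C(CC(=O)O)CC2` carries a free carboxylic acid on its side chain. In a functional assay on the whole organism (strain Wistar) for inhibition, with Rattus norvegicus as the target, read by paw edema, with stated times of 60 min and 1 h, at a dose of 100 mg/kg by the oral route (on this read-out lower numbers stand for less inhibition and higher numbers for more inhibition at the one dose given (going by the name of the read-out)), compound 1 gives 18.8%. Its one measured relative, compound 2 `COc1cc2c(cc1OC)C(CC(=O)N1CCOCC1)CC2`, in which the acid has become an amide, gives in this assay a value of 15.6%. The step of a number 3.2 percentage points lower from compound 1 to compound 2 (within the scatter) is within the scatter, so the two numbers cannot be placed one above the other, and compound 1 simply stands level with compound 2 on the two numbers shown.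

Compound 3 `COc1cc2c(cc1OC)C(CC(=O)NCCO)CC2` is the second amide of the series: (2-hydroxyethyl)amino in place of hydroxy on a carbonyl carbon. Among the compounds with values here, the only measured step that bears on it is the conversion of the same acid to a different amide, from compound 1 to compound 2, which moved the read-out by a number 3.2 percentage points lower from compound 1 to compound 2 (within the scatter), a shift within the scatter. On that basis the step of a number 2.8 percentage points lower from compound 1 to compound 3 (within the scatter) is expected to show no change beyond the scatter. Compound 3 is therefore estimated to give 16% in this assay, between 6% and 27%.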

Compound 3, a percentage reported as inhibition, in the whole organism at one dose (the size of the read-out at that dose, not a potency): 0%
Compound 3: middle estimate off by 16 percentage points, on the high side; measured number below the stated range.
By their numbers in this assay, from the lowest: compound 3; then compounds 2 and 1 (each within the scatter of the next).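

In this assay, the change on this carbonyl carbon is no longer neutral: (2-hydroxyethyl)amino in place of hydroxy gives a number 18.8 percentage points lower from compound 1 to compound 3 (beyond the scatter), and the same group in place of morpholin-4-yl gives a number 15.6 percentage points lower from compound 2 to compound 3 (beyond the scatter). The earlier step, a number 3.2 percentage points lower from compound 1 to compound 2 (within the scatter), had shown only that one amide stands level with the acid; these two steps show that turning the acid into an amide does not by itself fix the read-out, and that the outcome depends on which amine part is attached, with compound 3 alone falling clearly away from the other two. No measurement available here accounts for the drop seen with compound 3.

The compounds shown leave open whether the loss goes with the terminal hydroxy of the new chain or with the amide hydrogen that morpholin-4-yl lacks, a question that an ethylamino or a 2-methoxyethylamino group on the same carbonyl carbon could help to separate. They also leave open whether the pattern holds at other doses, since all three numbers come from a single oral dose.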